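Removing one bromo from compound 1: cytotoxicity outlook

The source may report more compounds than this note shows. Statements on the series, on what has been measured and on what is new or still open speak of the compounds shown alone.

Compound 1 `COc1c(Br)cc(Br)cc1C(=O)Nc1ccccc1` is the reference point of this series. In an ADME assay on HEK293 cells (Homo sapiens) for cytotoxicity, read by reporter gene assay and resazurin assay, with a stated time of 48 h (on this read-out lower numbers stand for higher toxicity in this test and higher numbers for lower toxicity in this test), compound 1 reports only a limit of the assay, > 100000 nM, not a number. Compound 2 `COc1c(Br)cccc1C(=O)Nc1ccc(Sc2nc3ccccc3s2)c(Cl)c1` is also known here. In this assay compound 2 likewise stops at the limit, > 100000 nM. Compound 3 `COc1c(Br)cc(Br)cc1C(=O)Nc1ccc(Sc2nc3ccccc3s2)cc1` completes the measured set. In this assay compound 3 again gives only the limit, > 100000 nM. Every measured value thus sits at the same place, (the limit of > 100000 nM in this assay, at which 3 of the 3 values shown sit), so compound 1 can be placed only at that limit, neither more nor less toxic than the others as far as these numbers reach.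

Compound 4 `COc1c(Br)cccc1C(=O)Nc1ccccc1` is not yet measured. It differs from compound 1 by hydrogen in place of bromo on an aromatic carbon. Among the measured compounds shown here, no comparison between measured compounds is available for this change, and nothing in the measured set distinguishes one compound from another in this assay. The step from compound 1 to compound 4 in this assay is therefore expected to be none beyond the scatter, a step that the limit leaves unreadable from compound 1 to compound 4. For compound 4 in this assay a value around 150000 nM is estimated, in the range 60000 nM to 400000 nM, most likely reported again only as a limit.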

Compound 4, half-maximal cytotoxic concentration: > 100000 nM
Compound 4: only a limit was reported; the forecaster's own chance of this, stated with the estimate: 90%; the middle value does not contradict the limit.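

No step can be read from compound 1 to compound 4 in this assay, because both report only a limit: the limit of > 100000 nM in this assay, at which 4 of the 4 values shown sit. The compounds shown leave open what hydrogen in place of bromo on an aromatic carbon does to cytotoxicity; none of them gives a number.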